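A few compounds are considered here, and "the series" means these few. Any claim that something is new, unique, unknown or untested is made for them only; others in the source may bear on it.

Compound 1 `O=C1/C(=C/c2ccc(F)cc2)CCC/C1=C\c1ccccc1[N+](=O)[O-]` gives 4.86 in a physicochemical assay for lipophilicity; a higher number here means a more lipophilic compound, a lower number a more polar compound; compound 2 `O=C1/C(=C/c2ccc(Cl)cc2)CCC/C1=C\c1ccccc1[N+](=O)[O-]` gives 4.86.

Compound 2 stands level with compound 1 at the digits shown, the step of no change at the digits printed from compound 1 to compound 2 (within the scatter) lying within the scatter. Compound 3 `O=C1/C(=C/c2ccccc2)CCC/C1=C\c1ccccc1[N+](=O)[O-]` differs from compound 2 by hydrogen in place of chloro on an aromatic carbon. For the measured compounds named here, the only measured step, no change at the digits printed from compound 1 to compound 2 (within the scatter), exchanges one halogen for another and thus bears only loosely on a change to hydrogen; no measured step removes a group outright. On that thin basis a modest drop in this assay is expected for compound 3, a step of a number 0.46 log units lower from compound 2 to compound 3 (beyond the scatter), giving an estimate of 4.4 with a range from 3.9 to 4.9.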

Compound 3, partition coefficient: 4.86
For compound 3 the middle estimate is 0.46 log units below the measured one; the range from low to high includes it.
By their numbers in this assay, from the lowest: compounds 1, 2 and 3 (each within the scatter of the next).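

With the halogen gone altogether, this assay shows no change at the digits printed from compound 2 to compound 3 (within the scatter), and likewise no change at the digits printed from compound 1 to compound 3 (within the scatter). Fluoro, chloro and hydrogen on this aromatic carbon, para to a large group, thus read level, so the earlier halogen swap was not the only exchange here to leave the read-out flat. No evidence at hand accounts for this flatness.

The three compounds span only these small substituents at a single place on the shared core. On these data alone, whether a methoxy group, an amine or a carboxylic acid at that carbon would also read level remains open.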